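A selenium-bearing group replaces 3-chloropropyl

This account rests on a few compounds, and the source may have more. Where it says the series, first, only, none or still open, it means among the compounds named here.

Measured in a functional assay on HCT-116 cells (Homo sapiens) for inhibition, read by MTT assay, with a stated time of 48 h; on this read-out lower numbers stand for stronger inhibition and higher numbers for weaker inhibition:
- compound 1 `CCCCC(=O)N(Cc1ccc(OC)c(O)c1)c1cc(OC)c(OC)c(OC)c1`: 170 nM
- compound 2 `COc1ccc(CN(C(=O)CO)c2cc(OC)c(OC)c(OC)c2)cc1O`: 520 nM
- compound 3 `COc1ccc(CN(C(=O)CCCCCl)c2cc(OC)c(OC)c(OC)c2)cc1O`: 220 nM

The measurements place compound 3 with compound 1 and apart from compound 2: they show a 1.3-fold higher number from compound 1 to compound 3 (0.11 log units; within the scatter), and a 2.4-fold lower number from compound 2 to compound 3 (0.37 log units; beyond the scatter). Compound 4 `COc1ccc(CN(C(=O)C[Se]C#N)c2cc(OC)c(OC)c(OC)c2)cc1O` carries a group of 3 heavy atoms (1 carbon, 1 nitrogen, 1 selenium; no ring) in place of a group of 4 heavy atoms (3 carbon, 1 chlorine; no ring), on a saturated chain carbon bound to a carbonyl carbon. Among the compounds with values here, no measured compound contains selenium, so the evidence is indirect. At this same place, the exchanges gave a 3.1-fold higher number from compound 1 to compound 2 (0.49 log units; beyond the scatter), and the step to compound 3 cited above. From the compounds shown here alone, both were modest, so a step beyond the scatter is not expected in this assay, and the direction remains open. The expected change is a 1.1-fold lower number from compound 3 to compound 4 (0.04 log units; within the scatter). For compound 4 the estimate is 200 nM, with an expected range of 70 nM to 550 nM.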

Compound 4, half-maximal inhibitory concentration: 310 nM
Estimate against measurement, compound 4: 1.6-fold (0.19 log units) below; measured number inside the range.
By their numbers in this assay, from the lowest: compounds 1, 3, 4 and 2 (each within the scatter of the next, the first and the last beyond it).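

In this assay the selenium-bearing group stays within the scatter of all three earlier compounds (a 1.4-fold higher number from compound 3 to compound 4 (0.15 log units; within the scatter); a 1.7-fold lower number from compound 2 to compound 4 (0.22 log units; within the scatter); a 1.8-fold higher number from compound 1 to compound 4 (0.26 log units; within the scatter)). This place, on a saturated chain carbon bound to a carbonyl carbon, thus takes selenium and a nitrile without a step beyond the scatter, even though compound 1 and compound 2 stand apart from each other. No measurement shown here explains this result. A thiocyanate or a methylselenyl group at this place would separate the selenium from the nitrile. The compounds shown leave open whether either part matters on its own.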